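A few compounds are considered here, and "the series" means these few. Any claim that something is new, unique, unknown or untested is made for them only; others in the source may bear on it.

Compound 1 `CCOC(=O)CN(C)C(=O)c1ccc(C(CC)(CC)c2ccc(OCC(O)C(C)(C)C)c(C)c2)n1CC` gives 210 nM in an assay on HL-60 cells for agonist activity at vitamin D3 receptor (Homo sapiens), read by microscopy, with a stated time of 96 h; on this read-out higher numbers stand for an effect only at larger amounts of compound and lower numbers for an effect already at smaller amounts. Compound 2 `CCn1c(C(=O)NCCCN(C)C)ccc1C(CC)(CC)c1ccc(OCC(O)C(C)(C)C)c(C)c1` gives 37 nM in this assay, which is a 5.7-fold lower number from compound 1 to compound 2 (0.75 log units; beyond the scatter). Compound 3 `CCn1c(C(=O)Nc2ccc(OC(F)(F)F)cc2)ccc1C(CC)(CC)c1ccc(OCC(O)C(C)(C)C)c(C)c1` shows no number but only a limit, > 50000 nM, as described by the limit of > 50000 nM in this assay, at which 1 of the 3 values shown sits. The steps of an at least 230-fold higher number from compound 1 to compound 3 (2.37 log units; beyond the scatter) and an at least 1300-fold higher number from compound 2 to compound 3 (3.13 log units; beyond the scatter) both place an aryl group on the amide-type nitrogen and are large. Compound 4 `CCn1c(C(=O)Nc2cccc(C(F)(F)F)c2)ccc1C(CC)(CC)c1ccc(OCC(O)C(C)(C)C)c(C)c1` differs from compound 3 by 3-(trifluoromethyl)phenyl in place of 4-(trifluoromethoxy)phenyl on an amide-type nitrogen. Going by the values given here, no measured step swaps one aryl group for another on that nitrogen, and compound 4 keeps an aryl amide like compound 3. Compound 4 is expected to change little, an at least 1.2-fold lower number from compound 3 to compound 4 (0.09 log units; that floor lies within the scatter). Compound 4 is estimated at 40000 nM in this assay, within 5000 nM to 100000 nM, most likely again a limit.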

Compound 4, half-maximal effective concentration: > 50000 nM
Compound 4 gave a limit, no number; the forecaster's own chance of this, stated with the estimate: 70%; middle value at least 1.2-fold (0.09 log units) away from the limit.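

With compound 4, a second aryl group on the amide-type nitrogen also ends at a limit, so this outcome is not confined to 4-(trifluoromethoxy)phenyl: the limit of > 50000 nM in this assay, at which 2 of the 4 values shown sit. The step of an at least 1300-fold higher number from compound 2 to compound 4 (3.13 log units; beyond the scatter) and the step of an at least 230-fold higher number from compound 1 to compound 4 (2.37 log units; beyond the scatter) are both large, as the steps to compound 3 were. The step between compound 3 and compound 4 cannot be read, since both values are limits.

The compounds shown leave open whether a 4-aminophenyl group or a benzyl group on that nitrogen would give a measurable number in this assay.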